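The source may hold more compounds than are shown below. What is called first, only, known or untested is meant among the compounds shown, and "the series" means these compounds.

Working notes on the series.

Compound 1 `CCn1c(C(=O)NCCN(C)C)ccc1C(CC)(CC)c1ccc(OCC(=O)C(C)(C)C)c(C)c1` gives 2300 nM in a functional assay on HepG2 cells (Homo sapiens), read by MTT assay, with a stated time of 48 h; on this read-out lower numbers stand for stronger inhibition and higher numbers for weaker inhibition. Compound 2 `CCn1c(C(=O)NCCN)ccc1C(CC)(CC)c1ccc(OCC(=O)C(C)(C)C)c(C)c1` gives 180 nM, and compound 3 `CCn1c(C(=O)NCCN(C)C)ccc1C(CC)(CC)c1ccc(OCC(O)C(C)(C)C)c(C)c1` gives 870 nM. Compound 3 therefore stands second highest of the three numbers: nearer to compound 1, with a 2.6-fold lower number from compound 1 to compound 3 (0.42 log units; beyond the scatter), and further from compound 2. The one large move seen so far is a 13-fold lower number from compound 1 to compound 2 (1.11 log units; beyond the scatter), at the chain end of the amide.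

Compound 4 `CCn1c(C(=O)OCc2ccc(F)cc2)ccc1C(CC)(CC)c1ccc(OCC(O)C(C)(C)C)c(C)c1` is not yet measured. Relative to compound 3 the change is (4-fluorobenzyl)oxy in place of (2-(dimethylamino)ethyl)amino on a carbonyl carbon. Neither measured step covers this. The step from compound 1 to compound 2 only shows that the number is sensitive to what sits at the end of that chain; the step from compound 1 to compound 3 concerns the other side of the molecule and is shared by compound 3 and compound 4 alike. Among the compounds with values here, no pair here exchanges the amide for an ester or removes the chain entirely, so the direction rests on weak ground.

Given that the only sizeable step involved the amine end of the chain, the expectation for compound 4 is a step toward a higher number, a 2.9-fold higher number from compound 3 to compound 4 (0.46 log units; beyond the scatter), with wide uncertainty. The estimate for compound 4 in this assay is 2500 nM, in the range 600 nM to 10000 nM.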

Compound 4, half-maximal inhibitory concentration: > 50000 nM
Compound 4: a limit, no number; the forecaster's own chance of this, stated with the estimate: 10%; middle value at least 20-fold (1.30 log units) away from the limit.
By their numbers in this assay, from the lowest: compound 2; then compound 3; then compound 1. At a limit, above all of these: compound 4.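

Within the data shown here, the carbonyl carbon on the shared core turns out to tolerate far less than the earlier compounds suggested: replacing (2-(dimethylamino)ethyl)amino with (4-fluorobenzyl)oxy gives an at least 57-fold higher number from compound 3 to compound 4 (1.75 log units; beyond the scatter). In this assay compound 4 stands at a limit of the assay and not at a number: the limit of > 50000 nM in this assay, at which 1 of the 4 values shown sits. Compound 1, compound 2 and compound 3 all keep the amide and its chain and all give numbers, and the side bearing the hydroxyl is the same in compound 3 and compound 4, so this step belongs wholly to the group on the carbonyl carbon and shows that this position can do more than tune the number through the end of the chain.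

The step changes the amide nitrogen to an ester oxygen, removes the terminal amine and brings in the fluorinated aromatic ring all at once, so the compounds shown do not tell which of these carries it. A 4-fluorobenzyl amide, or a 2-aminoethyl ester, would separate these parts, and a longer chain ending in a primary amine would test the end of the chain further.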